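The source may hold more compounds than are shown below. What is called first, only, known or untested is meant among the compounds shown, and "the series" means these compounds.

Compound 1, `CCCc1cnc(C(=O)/C=C/c2ccc(O)cc2)cn1`: 514000 nM
Compound 2, `CC(C)(C)c1ncc(C(=O)Nc2cc(O)cc(Cl)c2)nc1Cl`: 99000 nM

In a functional assay on the whole organism for inhibition, with Chlorella vulgaris as the target, read by spectrophotometry, with a stated time of 4 h (a higher number here means a weaker inhibitor, a lower number a stronger inhibitor), compound 1 gives 514000 nM, the highest of the two numbers shown. Compound 2 gives 99000 nM, a lower number and a gap beyond the scatter. Compound 3, `CC(C)Cc1cnc(C(=O)/C=C/c2ccc(O)cc2)cn1`, differs from compound 1 by methyl in place of hydrogen on a saturated chain carbon bound to two saturated chain carbons. Within the data shown here, no measured pair shows a change of this kind, so no firm direction can be read from the data; the most likely outcome is a step that stays within the scatter. Compound 3 is therefore expected to give about 400000 nM, with a range from 150000 nM to 1200000 nM. The expected step is a 1.3-fold lower number from compound 1 to compound 3 (0.11 log units; within the scatter).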

Compound 3, half-maximal inhibitory concentration: 232000 nM
Beside the measured number, compound 3's estimate is 1.7-fold (0.24 log units) above it; low and high end bracket the measured number.
By their numbers in this assay, from the lowest: compound 2; then compound 3; then compound 1.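

In this assay, replacing propyl with isobutyl on the core of compound 1 gives a 2.2-fold lower number from compound 1 to compound 3 (0.35 log units; beyond the scatter) and is a modest change. Among these compounds, this is the first measured step at this position, and it shows that methyl in place of hydrogen on a saturated chain carbon bound to two saturated chain carbons gives a stronger inhibitor. No measurement available here explains the gain. One step cannot establish a pattern. As far as these compounds go, whether a longer chain, such as pentyl, or an amine on the chain would strengthen or weaken inhibition remains open.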